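Aryl ether variation and intrinsic activity in the series

This account rests on a few compounds, and the source may have more. Where it says the series, first, only, none or still open, it means among the compounds named here.

Measured compounds:
compound 1 `Cc1cccc(Oc2cccc(COc3ccccc3CCC(=O)OCCCOP(=O)(O)OC[C@H](N)C(=O)O)c2)c1` — 0.29
compound 2 `N[C@@H](COP(=O)(O)OCCCOC(=O)CCc1ccccc1OCc1cccc(Oc2ccc(Cl)cc2)c1)C(=O)O` — 0.76

In an assay on cells for activation of probable G-protein coupled receptor 34 (Mus musculus), with a stated time of 1 h (a lower number here means a smaller maximal response, a higher number a larger maximal response), compound 1 gives 0.29, the lowest of the two numbers shown. Within the data shown here, compound 2 gives 0.76, and the step a number 0.47 higher from compound 1 to compound 2 (beyond the scatter) is the only measured step.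

Compound 3 `N[C@@H](COP(=O)(O)OCCCOC(=O)CCc1ccccc1OCc1cccc(Oc2ccc(I)cc2)c1)C(=O)O` is not yet measured. It differs from compound 1 as follows: 4-iodophenyl in place of 3-methylphenyl on an oxygen on an aromatic ring

Among the measured compounds shown here, the one measured step that bears on this change is a number 0.47 higher from compound 1 to compound 2 (beyond the scatter), which sits at the same place and also exchanges 3-methylphenyl for a 4-halophenyl group. On that basis an upward step of comparable size is expected for compound 3, a number 0.43 higher from compound 1 to compound 3 (beyond the scatter), though with a single precedent the size is uncertain. The estimate for compound 3 is 0.72, expected to fall between 0.5 and 0.92.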

Compound 3, intrinsic activity: the largest response reached, as a fraction of the reference agonist's: 0.82
Compound 3: middle estimate off by 0.10, on the low side; low and high end bracket the measured number.
By their numbers in this assay, from the lowest: compound 1; then compounds 2 and 3 (each within the scatter of the next).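

In this assay the exchange of 3-methylphenyl for 4-iodophenyl on this oxygen gives a number 0.53 higher from compound 1 to compound 3 (beyond the scatter), so the large gain seen earlier with 4-chlorophenyl is not confined to a single halogen. Iodo in place of chloro on the aromatic carbon gives a number 0.060 higher from compound 2 to compound 3 (within the scatter), so these two halogens cannot be told apart in this read-out. Nothing available accounts for the higher maximal response.

The compounds shown leave open whether the gain follows the halogen or its place on the ring, since both steps from compound 1 change the group and its place together; 4-methylphenyl or 3-chlorophenyl would separate the two. Also open, as far as these compounds go, is whether a halogen is needed at all, which an unsubstituted phenyl or a 4-methoxyphenyl would begin to test.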